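The source may hold more compounds than are shown below. What is called first, only, known or untested is meant among the compounds shown, and "the series" means these compounds.

Measured so far in an ADME assay on liver (Rattus norvegicus) for metabolic stability, read by LC-MS, using S9 fraction and NADPH, with a stated time of 30 min, tested at 5 uM, in the presence of a further agent that is not named here; a higher number here means faster removal of the compound, a lower number slower removal:
Compound 1 `CN(C)c1nonc1/C(=N/O)Nc1ccc(F)c(Br)c1`: > 36.6 mL/min/kg, a limit and not a number
Compound 2 `CC(=O)NCCNc1nonc1/C(=N/O)Nc1ccc(F)c(Br)c1`: 33.3 mL/min/kg

Among the measured compounds shown here, compound 2 gives 33.3 mL/min/kg, the only actual number in this assay so far. For compound 1 the reading is a limit: the limit of > 36.6 mL/min/kg in this assay, at which 1 of the 2 values shown sits.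

Compound 3 `CS(=O)(=O)NCCNc1nonc1/C(=N/O)Nc1ccc(F)c(Br)c1` differs from compound 2 by one change, methylsulfonyl in place of acetyl on an amine nitrogen. For the measured compounds named here, the one measured step, an at least 1.0-fold lower number from compound 1 to compound 2 (0.04 log units; that floor lies within the scatter), concerned another change, (2-acetamidoethyl)amino in place of dimethylamino on an aromatic carbon. Going by the values given here, it therefore bears only loosely on this one, and no measured pair tests the new change directly. No shift beyond the scatter is expected in this assay, and the expected step is a 1.1-fold lower number from compound 2 to compound 3 (0.05 log units; within the scatter). Compound 3 is estimated at 30 mL/min/kg, with an expected range of 17 mL/min/kg to 37 mL/min/kg.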

Compound 3, clearance: 25 mL/min/kg
Compound 3: middle estimate off by 1.2-fold (0.08 log units), on the high side, and the stated range covers the measured number.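

In this assay, methylsulfonyl in place of acetyl on an amine nitrogen gives a 1.3-fold lower number from compound 2 to compound 3 (0.12 log units; within the scatter), so at this position the exchange produces no shift beyond the scatter, and compound 2 and compound 3 cannot be told apart. With (2-(methanesulfonamido)ethyl)amino in place of dimethylamino on an aromatic carbon, the reading is an at least 1.4-fold lower number from compound 1 to compound 3 (0.16 log units; that floor lies within the scatter), which is a floor and supports no claim of a real difference. The reading for compound 1 remains a limit and not a number: the limit of > 36.6 mL/min/kg in this assay, at which 1 of the 3 values shown sits.

From the compounds shown here alone, whether a urea or a carboxylic acid on the same amine nitrogen would move clearance beyond the scatter stays open. So does the effect of a longer chain in place of the 2-(methanesulfonamido)ethyl group.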